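Sulfonyl aryl swap on the shared core

The source may report more compounds than this note shows. Statements on the series, on what has been measured and on what is new or still open speak of the compounds shown alone.

Compound 1 `CC1CCN(c2c(S(=O)(=O)c3cc(Cl)cc(Cl)c3)cnc3c(F)cccc23)CC1` carries a 3,5-dichlorophenyl on the sulfonyl sulfur. In an assay on isolated protein for displacement of a labelled ligand from metabotropic glutamate receptor 5 (Homo sapiens), with a stated time of 60 min, tested at 1 uM (on this read-out higher numbers stand for more inhibition at the one concentration tested (going by the name of the read-out) and lower numbers for less inhibition), compound 1 gives 82%, the second highest of the three numbers in hand. Compound 2 `Cc1ccc(S(=O)(=O)c2cnc3ccc(F)cc3c2N2CCC(C)CC2)cc1F` is the nearest: in this assay compound 2 gives 86%, a number within the scatter of that of compound 1, so the two are not separated. Compound 3 `CC1CCN(c2c(S(=O)(=O)c3ccccc3)cnc3ccc(Cl)cc23)CC1` lies furthest away: in this assay compound 3 gives 59%, beyond the scatter below compound 1. No two of these compounds differ in one place only, so no single change can be tied to a step; compound 3 carries an unsubstituted phenyl on the sulfonyl sulfur and a different substituent on the core, and which of these matters cannot be told from three numbers.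

Compound 4 `CC1CCN(c2c(S(=O)(=O)c3cccc(F)c3)cnc3c(F)cccc23)CC1` is not yet measured. It differs from compound 1 in one place: 3-fluorophenyl in place of 3,5-dichlorophenyl on a sulfonyl sulfur. The ring on the sulfonyl sulfur keeps a single halogen, so a modest downward step is expected in this assay, near the edge of the scatter rather than a collapse toward compound 3. Compound 4 is expected to give 70%, between 50% and 88%. The estimated step is a number 12 percentage points lower from compound 1 to compound 4 (beyond the scatter).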

Compound 4, a percentage reported as inhibition, at one concentration (the size of the read-out at that concentration, not a potency): 62%
Compound 4: the middle estimate sits 8 percentage points above what was measured; measured number inside the range.
By their numbers in this assay, from the lowest: compounds 3 and 4 (each within the scatter of the next); then compounds 1 and 2 (each within the scatter of the next).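

For the compounds shown here, with the rest of compound 1 held fixed, 3-fluorophenyl in place of 3,5-dichlorophenyl on the sulfonyl sulfur gives a number 20 percentage points lower from compound 1 to compound 4 (beyond the scatter) in this assay, the first clean evidence that the group at this position affects the read-out. The swap changes both the identity and the number of the halogens on the ring, so this single step cannot show which of the two accounts for the loss. Going by these compounds alone, nothing measured so far explains the step.

The compounds shown leave open how a 3-chlorophenyl would read on the same core, which would separate the halogen's identity from the number of halogens, and whether a ring bearing a methoxy group or a nitrile, with no halogen at all, would hold up at this position. As far as these compounds go, because the read-out reports inhibition at one concentration only, it also remains open how the step would translate into a difference in potency across a full concentration series.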